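The source may hold more compounds than are shown below. What is called first, only, known or untested is meant among the compounds shown, and "the series" means these compounds.

Measured compounds:
Compound 1, `Cc1cn([C@@H]2O[C@H](CO[Si](C)(C)C(C)(C)C)[C@@]3(OS(=O)(=O)C=C3NCCC(=O)OCc3ccccc3)[C@H]2O[Si](C)(C)C(C)(C)C)c(=O)n(C)c1=O`, in a functional assay on CCRF-CEM cells (Homo sapiens) (a lower number here means that less compound is tolerated, a higher number that more compound is tolerated), gives > 250000 nM, which is a limit of the assay and not a number.
Compound 2, `Cc1cn([C@@H]2O[C@H](CO[Si](C)(C)C(C)(C)C)[C@@]3(OS(=O)(=O)C=C3NC(N)=O)[C@H]2O[Si](C)(C)C(C)(C)C)c(=O)n(C)c1=O`, in this assay gives 4360 nM.

Going by the values given here, compound 2 thus holds the only real number among the two values shown; the other value is a limit. Among the compounds with values here, the one measured step, an at least 57-fold lower number from compound 1 to compound 2 (1.75 log units; beyond the scatter), is large and beyond the scatter.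

Compound 3, `COC(=O)CCNC1=CS(=O)(=O)O[C@@]12[C@@H](CO[Si](C)(C)C(C)(C)C)O[C@@H](n1cc(C)c(=O)n(C)c1=O)[C@@H]2O[Si](C)(C)C(C)(C)C`, differs from compound 2 by 2-(methoxycarbonyl)ethyl in place of carbamoyl on an amine nitrogen. Within the data shown here, the only step that bears on this change runs the other way: an at least 57-fold lower number from compound 1 to compound 2 (1.75 log units; beyond the scatter) replaced a chain carrying an ester with carbamoyl and lowered the number strongly. Compound 3 reinstates a chain carrying an ester, 2-(methoxycarbonyl)ethyl, so the number is expected to climb, by about a 23-fold higher number from compound 2 to compound 3 (1.36 log units; beyond the scatter), with the chance that the assay again reports only a limit, as it did for compound 1 (the limit of > 250000 nM in this assay, at which 1 of the 2 values shown sits). Compound 3 is therefore estimated at 100000 nM, with a range from 20000 nM to 250000 nM.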

Compound 3, half-maximal cytotoxic concentration: > 250000 nM
Compound 3 gave a limit, no number; the forecaster's own chance of this, stated with the estimate: 40%; at least 2.5-fold (0.39 log units) between middle value and limit.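

The change from carbamoyl to 2-(methoxycarbonyl)ethyl on the amine nitrogen gives an at least 57-fold higher number from compound 2 to compound 3 (1.75 log units; beyond the scatter) in this assay, so the large gap seen earlier does not depend on the 2-(benzyloxycarbonyl)ethyl chain of compound 1 alone. The step between compound 1 and compound 3 cannot be read, as both values are limits and not numbers. Of the compounds shown, only compound 2, with carbamoyl, gives a real number, and the two ester chains both end at the same limit: the limit of > 250000 nM in this assay, at which 2 of the 3 values shown sit.

As far as these compounds go, how far the true values of compound 1 and compound 3 lie from that limit stays open, so the two ester chains cannot be ranked. From the compounds shown here alone, it is also open whether the low number needs the ureido group itself, or whether an acetamide, a methylurea or a chain ending in a carboxylic acid on this nitrogen would give a number too.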